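Compound 3 to compound 4: fluoro in place of methyl

This account rests on a few compounds, and the source may have more. Where it says the series, first, only, none or still open, it means among the compounds named here.

In a functional assay on B16-F10 cells (Mus musculus) for antiproliferative activity, read by MTT assay, with a stated time of 48 h (a lower number here means a stronger inhibitor, a higher number a weaker inhibitor), compound 3 (`Cc1ccc(NCc2cn(-c3ccccc3)nc2-c2ccc(C)cc2)cc1`) gives 7380 nM and stands level with compound 2 (`COc1ccc(-c2nn(-c3ccccc3)cc2CNc2ccc(C)cc2)cc1`) at 8380 nM within the scatter. Compound 1 (`Fc1ccc(NCc2cn(-c3ccccc3)nc2-c2ccc(Cl)cc2)cc1`) at 2120 nM gives a lower number than compound 3, and that gap lies beyond the scatter.

Compound 4 (`Cc1ccc(-c2nn(-c3ccccc3)cc2CNc2ccc(F)cc2)cc1`) carries fluoro in place of methyl on an aromatic carbon, para to a large group, so that (4-methylphenyl)amino becomes (4-fluorophenyl)amino (fluoro in place of methyl on an aromatic carbon).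

Among the compounds with values here, no measured step isolates this change. Within the data shown here, the only step in hand, a 1.1-fold lower number from compound 2 to compound 3 (0.06 log units; within the scatter), is a different substitution in a different place and stays within the scatter, so it sets no size for this one. Compound 1 is the closer guide, as it shares the (4-fluorophenyl)amino group with compound 4 but also differs from compound 4 in a second place. The gap between compound 3 at 7380 nM and compound 1 at 2120 nM therefore cannot be assigned to fluoro alone, and only part of it is carried over. The expected change is a 1.8-fold lower number from compound 3 to compound 4 (0.24 log units; within the scatter), towards a lower number and possibly no larger than the scatter. Compound 4 is estimated at 4200 nM with an expected range of 1900 nM to 8500 nM in this assay.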

Compound 4, half-maximal inhibitory concentration: 5670 nM
Beside the measured number, compound 4's estimate is 1.4-fold (0.13 log units) below it; the measured number falls inside the stated range.
By their numbers in this assay, from the lowest: compound 1; then compounds 4, 3 and 2 (each within the scatter of the next).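

In this assay, the change from (4-methylphenyl)amino to (4-fluorophenyl)amino, on an aromatic carbon para to a large group, gives no readable difference (a 1.3-fold lower number from compound 3 to compound 4 (0.11 log units; within the scatter)), so within this pair the position accepts fluoro and methyl alike. With (4-fluorophenyl)amino held fixed, the series also gains its first single-place step beyond the scatter (a 2.7-fold higher number from compound 1 to compound 4 (0.43 log units; beyond the scatter)), with methyl in place of chloro at the other substituted aromatic carbon; this makes that site, not the (4-methylphenyl)amino position, the one where a readable difference has been seen so far, though on a single pair and with a modest step. No measurement bearing on the cause of either step is available, and neither can be explained from these data.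

Going by these compounds, it remains open whether the (4-fluorophenyl)amino position stays this flat with a very different group in that place, such as a dimethylamino group, a carboxylic acid or a longer alkyl chain. On these data alone, it also remains open whether the difference between chloro and methyl persists with a partner other than (4-fluorophenyl)amino, and how a bromo or a trifluoromethyl group would read at that site.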